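This account rests on a few compounds, and the source may have more. Where it says the series, first, only, none or still open, it means among the compounds named here.

Compound 1 `C#CCSc1nc(Nc2ccccc2)c2ccncc2n1`: 16200 nM
Compound 2 `C#CCSc1nc(Nc2cccc(Cl)c2)c2ccncc2n1`: 2190 nM

In a functional assay on MGC-803 cells (Homo sapiens) for inhibition, read by MTT assay, with a stated time of 72 h (on this read-out lower numbers stand for stronger inhibition and higher numbers for weaker inhibition), compound 2 has the lower of the two numbers, 2190 nM. Compound 3 `C#CCSc1nc(Nc2cccc(O)c2)c2ccncc2n1` carries hydroxy in place of chloro on an aromatic carbon. Among the compounds with values here, only one measured step bears on this change: a 7.4-fold lower number from compound 1 to compound 2 (0.87 log units; beyond the scatter), seen with chloro in place of hydrogen on an aromatic carbon. Within the data shown here, no measured compound carries hydroxy, so the guide is indirect. With chloro gone, part of that gain is expected to be lost, giving a higher number. The expected step is a 2.7-fold higher number from compound 2 to compound 3 (0.44 log units; beyond the scatter). For compound 3 the estimated value is 6000 nM, with an expected range of 1800 nM to 20000 nM.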

Compound 3, half-maximal inhibitory concentration: 15700 nM
Compound 3: the middle estimate sits 2.6-fold (0.42 log units) below what was measured; measured number inside the range.
By their numbers in this assay, from the lowest: compound 2; then compounds 3 and 1 (each within the scatter of the next).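

In this assay the gain seen with chloro does not carry over to hydroxy at this place on the ring: 3-hydroxyphenyl in place of 3-chlorophenyl gives a 7.2-fold higher number from compound 2 to compound 3 (0.86 log units; beyond the scatter) in this pair. Against the ring with only hydrogen there, hydroxy gives a 1.0-fold lower number from compound 1 to compound 3 (0.01 log units; within the scatter) and so leaves compound 3 level with compound 1. A group at this place therefore does not bring a lower number by itself; the outcome depends on which group it is. No measured evidence explains the difference between chloro and hydroxy. On these data alone, whether an amine or a methoxy group here would behave like chloro or like hydroxy remains open.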